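Cyclobutyl for butyl on an aminophenyl thiadiazoline amide

The compounds below may be only part of what the source reports. "The series", "measured", "known", "first", "only" and "open" are said of these compounds alone.

Measured compounds:
Compound 1 `CCCCC(=O)N1N=C(c2cc(OC)ccc2N)SC1(C)C`: 101%
Compound 2 `COc1ccc(N)c(C2=NN(C(=O)C3CCC3)C(C)(C)S2)c1`: 57.8%
Compound 3 `CCCCC(=O)N1N=C(c2ccccc2N)SC1(C)C`: 39.1%

In an assay on isolated protein for inhibition of Nitric oxide synthase, inducible (Homo sapiens), read by scintillation counting, with a stated time of 30 min, tested at 50 uM (a lower number here means less inhibition, a higher number more inhibition at the concentration tested (going by the name of the read-out)), compound 1 gives 101%. The change cyclobutyl in place of butyl on a carbonyl carbon gives a number 43.2 percentage points lower from compound 1 to compound 2 (beyond the scatter). Compound 3 differs from compound 1 by hydrogen in place of methoxy on an aromatic carbon, giving a number 61.9 percentage points lower from compound 1 to compound 3 (beyond the scatter), and compound 3 stands lowest of the three. Compound 4 `CC1(C)SC(c2ccccc2N)=NN1C(=O)C1CCC1` is not yet measured; it differs from compound 3 by cyclobutyl in place of butyl on a carbonyl carbon, the same change as from compound 1 to compound 2, with the same surroundings. A drop is therefore expected from compound 3 to compound 4, estimated as a number 24.1 percentage points lower from compound 3 to compound 4 (beyond the scatter), smaller than the earlier step because a number 43.2 percentage points lower from compound 1 to compound 2 (beyond the scatter) started from a high number while compound 3 starts from a low one. Compound 4 is expected to give about 15%, likely between -5% and 35%.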

Compound 4, a percentage reported as inhibition, at one concentration (the size of the read-out at that concentration, not a potency): 46.9%
Compound 4: middle estimate off by 31.9 percentage points, on the low side, and the stated range ends below it.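

In this assay, cyclobutyl in place of butyl on the carbonyl carbon gives a number 7.8 percentage points higher from compound 3 to compound 4 (within the scatter) on the core without methoxy, so the clear drop seen on the methoxy core does not carry over: the same change on two cores in this assay, a number 43.2 percentage points lower (beyond the scatter) from compound 1 to compound 2 and a number 7.8 percentage points higher (within the scatter) from compound 3 to compound 4, 51 percentage points apart, beyond the scatter of two such steps. Hydrogen in place of methoxy likewise gives a number 10.9 percentage points lower from compound 2 to compound 4 (beyond the scatter) when cyclobutyl is present, so the size of this step also depends on the other group: the same change on two cores in this assay, a number 61.9 percentage points lower (beyond the scatter) from compound 1 to compound 3 and a number 10.9 percentage points lower (beyond the scatter) from compound 2 to compound 4, 51 percentage points apart, beyond the scatter of two such steps. The two changes therefore do not simply add in these four compounds, but one pair of cores cannot show why, nor how far this extends to other cores.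

The compounds shown leave open how a cyclopentyl group or a longer chain such as hexyl would behave on the carbonyl carbon. They also leave open whether an ethoxy group or a fluorine in place of methoxy would shift the result in the same way.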